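The compounds below may be only part of what the source reports. "The series", "measured", "known", "first", "only" and "open" are said of these compounds alone.

Measured so far:
compound 1 `COc1ccc(CN(C(=O)CSC(=S)N2CCN(C(=O)OC(C)(C)C)CC2)c2cc(OC)c(OC)c(OC)c2)cc1` gives 620 nM in a functional assay on HCT-116 cells (Homo sapiens) for inhibition, read by CCK-8 assay, with a stated time of 48 h; a lower number here means a stronger inhibitor, a higher number a weaker inhibitor;
compound 2 `COc1ccc(CN(C(=O)CSC(=S)N2CCN(Cc3ccc(C(C)(C)C)cc3)CC2)c2cc(OC)c(OC)c(OC)c2)cc1` gives 6890 nM in this assay.

Going by the values given here, compound 1 has the lowest of the two numbers; the only neighbour, compound 2, lies an 11-fold higher number from compound 1 to compound 2 (1.05 log units; beyond the scatter) away, which is a large step. The new compound, compound 3 `COc1ccc(CN(C(=O)CSC(=S)N2CCN(C(=O)OC(C)(C)C)CC2)c2ccc(C)cc2)cc1`, differs from compound 1 in a different place: 4-methylphenyl in place of 3,4,5-trimethoxyphenyl on an amide-type nitrogen. Among the compounds with values here, no measured step touches this part of the molecule, since the step from compound 1 to compound 2 changes the group on the ring nitrogen and leaves the amide-type nitrogen untouched. The expectation for compound 3 therefore rests on no directly comparable change and must be held loosely. A weakening is expected, of the size a 4.0-fold higher number from compound 1 to compound 3 (0.61 log units; beyond the scatter), but with a wide range that still allows a number close to that of compound 1. The estimate for compound 3 in this assay is 2500 nM, between 500 nM and 12000 nM.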

Compound 3, half-maximal inhibitory concentration: > 20000 nM
Compound 3: only a limit was reported; the forecaster's own chance of this, stated with the estimate: 10%; at least 8.0-fold (0.90 log units) between middle value and limit.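

Going by these compounds alone, putting 4-methylphenyl in place of 3,4,5-trimethoxyphenyl on the amide-type nitrogen gives an at least 32-fold higher number from compound 1 to compound 3 (1.50 log units; beyond the scatter), so a change at this nitrogen, and not only one on the ring nitrogen, can bring a large loss of strength. In this assay compound 3 gives > 20000 nM, which is a limit of the assay and not a number. The step is therefore only a minimum, and the true value of compound 3 stays unknown: the limit of > 20000 nM in this assay, at which 1 of the 3 values shown sits.

This single change removes the three methoxy groups and adds a methyl group at once, so the compounds shown cannot tell which of the two matters. A plain phenyl or a 4-methoxyphenyl on the same nitrogen would help to separate these two parts of the change.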